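Pyridine Replaces Nitrile on the Cyclopropane of Compound 2

A few compounds are considered here, and "the series" means these few. Any claim that something is new, unique, unknown or untested is made for them only; others in the source may bear on it.

Compound 1 `O=C([C@@H]1C[C@H]1c1ccccc1)N(CC1CCCNC1)c1ccc(-c2ccccc2)cc1` gives 10 nM in a functional assay for agonist activity at G protein-coupled receptor 88 (Homo sapiens), read by HTRF and cAMP accumulation; on this read-out lower numbers stand for an effect already at smaller amounts and higher numbers for an effect only at larger amounts of compound. Compound 2 `CC[C@H](C)[C@H](N)CN(C(=O)[C@@H]1C[C@H]1c1ccc(C#N)cc1)c1ccc(-c2ccccc2)cc1` stands far from that: in this assay compound 2 returns only a limit, > 25000 nM, so no number is known for it, and it sits at the limit of > 25000 nM in this assay, at which 1 of the 2 values shown sits. Compound 3 `CC[C@H](C)[C@H](N)CN(C(=O)[C@@H]1C[C@H]1c1ccncc1)c1ccc(-c2ccccc2)cc1` differs from compound 2 in one place, (pyridin-4-yl in place of 4-cyanophenyl on a saturated ring carbon). Among the compounds with values here, no measured step of this kind is at hand, so the step is expected to stay within the usual scatter, with the value most likely remaining near the limit, an at least 1.2-fold lower number from compound 2 to compound 3 (0.09 log units; that floor lies within the scatter). Compound 3 is therefore estimated at 20000 nM, with a range from 3000 nM to 60000 nM.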

Compound 3, half-maximal effective concentration: 1500 nM
For compound 3 the middle estimate is 13-fold (1.12 log units) above the measured one; the whole stated range lies above it.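

Within the data shown here, the first single-place change in this set shows that the group on this saturated ring carbon of the three-membered ring can move the result substantially: pyridin-4-yl in place of 4-cyanophenyl gives an at least 16-fold lower number from compound 2 to compound 3 (1.22 log units; beyond the scatter) in this assay. The true size of the step remains unknown, because compound 2 returns only a limit: the limit of > 25000 nM in this assay, at which 1 of the 3 values shown sits.

Still open, as far as these compounds go, is how a pyridin-3-yl or a 4-methoxyphenyl group would read on the same ring carbon. From the compounds shown here alone, it is also open whether the step from 4-cyanophenyl to pyridin-4-yl would carry over to the core of compound 1.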